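The source may report more compounds than this note shows. Statements on the series, on what has been measured and on what is new or still open speak of the compounds shown alone.

Measured so far in a functional assay on thoracic aorta (Rattus norvegicus, strain Wistar), with a stated time of 15 min; a lower number here means that less compound is needed, a higher number that more compound is needed for the effect:

Compound 1, `COc1ccc(Br)cc1C(C)NC(=O)NS(=O)(=O)c1ccc(C)cc1`, gives > 300000 nM; this is a limit of the assay, not a number.
Compound 3, `COc1ccc(F)cc1C(C)NC(=O)NS(=O)(=O)c1ccc(C)cc1`, gives > 300000 nM; this too is a limit of the assay, not a number.
For the measured compounds named here, compound 2, `CCOc1ccc(Br)cc1C(C)NC(=O)N(C)S(=O)(=O)c1ccccc1`, gives 19800 nM, the only number among the three.

Compound 1 and compound 3 share one core and differ in a single place: fluoro in place of bromo on an aromatic carbon. The step that the two limits leave unreadable from compound 1 to compound 3 has no readable size because of the limit of > 300000 nM in this assay, at which 2 of the 3 values shown sit, so nothing can be said about what this change did there. Compound 2 stands on a different core; the difference between the two cores is not broken down here, and its value therefore cannot be set against compound 1 or compound 3 by a single step.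

Compound 4, `CCOc1ccc(F)cc1C(C)NC(=O)N(C)S(=O)(=O)c1ccccc1`, is not yet measured. It differs from compound 2 by fluoro in place of bromo on an aromatic carbon. Going by the values given here, this is the same kind of change as the one from compound 1 to compound 3, but not the same: there the fluoro stands para to a methoxy group, here para to an ethoxy group.

Among the compounds with values here, since the earlier step gives no size to carry over, the expectation for compound 4 rests on compound 2 alone, whose value 19800 nM is the only number known. The step from compound 2 to compound 4 is expected to be a 1.5-fold higher number from compound 2 to compound 4 (0.18 log units; within the scatter), with wide uncertainty in both directions. Compound 4 is therefore estimated to give 30000 nM in this assay , expected to lie between 6000 nM and 200000 nM.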

Compound 4, half-maximal effective concentration: 11500 nM
Compound 4: the middle estimate sits 2.6-fold (0.42 log units) above what was measured, and the stated range covers the measured number.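

In this assay, fluoro in place of bromo on the core of compound 2 gives a 1.7-fold lower number from compound 2 to compound 4 (0.24 log units; within the scatter), so on this core, with the fluoro para to an ethoxy group, bromo and fluoro cannot be told apart. The same change on the core of compound 1 cannot be read, because both ends of that step are limits of the assay and not numbers: the limit of > 300000 nM in this assay, at which 2 of the 4 values shown sit. This leaves a single readable size for the change, so the result shows that a bromo-to-fluoro swap on the core of compound 2 can be made without a difference beyond the scatter, but it does not show that the change behaves alike on both cores, since there is no second size to set beside it.

Only bromo and fluoro appear at this aromatic carbon among the compounds shown, so what a chloro group, a nitrile or an amine would do there remains open. Also open, as far as these compounds go, is whether a longer chain than ethoxy, such as propoxy, would give a readable difference on the core of compound 2.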